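Moving Two Fluorines Around a Benzoyl Ring

The compounds below may be only part of what the source reports. "The series", "measured", "known", "first", "only" and "open" are said of these compounds alone.

Compound 1, `CN(C(=O)NC(=O)c1c(F)cccc1F)c1nc(C(F)(F)F)c(C(=O)N/N=C/c2cc(C(F)(F)F)cc(C(F)(F)F)c2)s1`: in a functional assay on BCG823 cells (Homo sapiens) for inhibition, read by MTT assay, with a stated time of 72 h (a lower number here means a stronger inhibitor, a higher number a weaker inhibitor), compound 1 gives 5.28 ug/mL.
Compound 3, `CN(C(=O)NC(=O)c1ccccc1F)c1nc(C(F)(F)F)c(C(=O)N/N=C/c2cccc(C(F)(F)F)c2)s1`: in this assay compound 3 gives 16.3 ug/mL.
Compound 2, `CNc1nc(C(F)(F)F)c(C(=O)N/N=C/c2ccccc2C(F)(F)F)s1`: for compound 2 the result in this assay is only a limit, > 100 ug/mL.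

Among the two numbers reported, compound 1 has the lowest; the nearest is compound 3, whose higher number lies beyond the usual scatter of repeated measurements. Compound 2 stands only at the limit noted above (the limit of > 100 ug/mL in this assay, at which 1 of the 3 values shown sits).

The step from compound 1 leads to compound 4, `CN(C(=O)NC(=O)c1ccc(F)c(F)c1)c1nc(C(F)(F)F)c(C(=O)N/N=C/c2cc(C(F)(F)F)cc(C(F)(F)F)c2)s1`, which is not yet measured. The two have the same atoms, joined differently: 3,4-difluorophenyl in place of 2,6-difluorophenyl on a carbonyl carbon. The part of the molecule carrying the hydrazone and the two trifluoromethyl groups stays as it is.

Within the data shown here, no measured pair differs in only this way, so the expectation rests on the shared core and on the value of compound 1 alone. The step of a 1.4-fold higher number from compound 1 to compound 4 (0.15 log units; within the scatter) is expected to be small, at most a mild weakening, and may well fall within the scatter. Compound 4 is therefore estimated at 7.5 ug/mL, with a range from 2.5 ug/mL to 22 ug/mL.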

Compound 4, half-maximal inhibitory concentration: 3.51 ug/mL
Beside the measured number, compound 4's estimate is 2.1-fold (0.33 log units) above it; the measured number falls inside the stated range.
By their numbers in this assay, from the lowest: compounds 4 and 1 (each within the scatter of the next); then compound 3. At a limit, above all of these: compound 2.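

In this assay the move from the 2,6-difluorophenyl to the 3,4-difluorophenyl group on this carbonyl carbon gives a 1.5-fold lower number from compound 1 to compound 4 (0.18 log units; within the scatter) and so leaves the two compounds indistinguishable. Among these compounds, the earlier compounds held no pair differing only here, so this is the first direct sign that this ring can carry its two fluorines in either of these two arrangements without a clear change in the number. Nothing measured here offers a reason for this, and the limit reported for compound 2 does not bear on it.

Still open, on these data alone, is what a ring carrying a methoxy group or an amine in place of fluorine would give at this carbonyl carbon, and whether the fluorines are needed at all. Compound 3 differs from compound 1 in more than one place, so it cannot settle the effect of a single fluorine.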